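Fluoro in Place of Chloro on the Pendant Phenyl

The compounds below may be only part of what the source reports. "The series", "measured", "known", "first", "only" and "open" are said of these compounds alone.

Compound 2 `Cn1cc(/C=C2/C(=O)Nc3ccccc32)c2cc(Nc3nccc(-c4ccc(Cl)cc4)n3)ccc21` stands lowest of the two numbers shown, though its nearest neighbour, compound 1 `Cn1cc(/C=C2/C(=O)Nc3ccccc32)c2cc(Nc3nccc(-c4ccccc4)n3)ccc21`, is within the scatter. In a functional assay on MCF7 cells (Homo sapiens) for cytotoxicity, read by MTT assay, with a stated time of 48 h (a higher number here means a weaker inhibitor, a lower number a stronger inhibitor), compound 2 gives 23500 nM, and compound 1 gives 42900 nM. Compound 3 `Cn1cc(/C=C2/C(=O)Nc3ccccc32)c2cc(Nc3nccc(-c4ccc(F)cc4)n3)ccc21` differs from compound 2 by a single change, (fluoro in place of chloro on an aromatic carbon). For the measured compounds named here, the only measured step that touches this aromatic carbon is the one a 1.8-fold lower number from compound 1 to compound 2 (0.26 log units; within the scatter), where chloro replaced hydrogen and the number stayed within the scatter. With that step so small, a swap of one halogen for another at the same place is expected to give no step beyond the scatter in this assay, and the expected move is a 1.3-fold higher number from compound 2 to compound 3 (0.11 log units; within the scatter). Compound 3 is therefore estimated at 30000 nM in this assay, with a range from 15000 nM to 60000 nM.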

Compound 3, half-maximal inhibitory concentration: 48100 nM
Estimate against measurement, compound 3: 1.6-fold (0.21 log units) below; the measured number falls inside the stated range.
By their numbers in this assay, from the lowest: compounds 2, 1 and 3 (each within the scatter of the next, the first and the last beyond it).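

For the compounds shown here, the 4-chlorophenyl to 4-fluorophenyl change gives the first step at this aromatic carbon to pass the scatter, and it does so only modestly, with a 2.0-fold higher number from compound 2 to compound 3 (0.31 log units; beyond the scatter). Fluoro in place of hydrogen gives no such step, with a 1.1-fold higher number from compound 1 to compound 3 (0.05 log units; within the scatter), so in this assay the two halogens can be told apart at this place, while neither can be told apart from the hydrogen of compound 1. Nothing in the data given accounts for the gap between the two halogens.

From the compounds shown here alone, whether this small separation extends to other groups at the same aromatic carbon stays open, for example bromo, methoxy or an amine. Going by these compounds, it is also open whether a larger group there, such as a carboxylic acid or a longer chain, would move the number further than either halogen.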